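A Benzyl Exchange on the Sulfur

The compounds below may be only part of what the source reports. "The series", "measured", "known", "first", "only" and "open" are said of these compounds alone.

Measured in a functional assay on HepG2 cells (Homo sapiens) for antiproliferative activity, read by MTT assay, with a stated time of 24 h; on this read-out lower numbers stand for stronger inhibition and higher numbers for weaker inhibition:
compound 1 `Sc1nnc(-c2ccc3c(c2)OCCO3)n1-c1ccccc1` gives 60000 nM
compound 2 `O=[N+]([O-])c1cccc(CSc2nnc(-c3ccc4c(c3)OCCO4)n2-c2ccccc2)c1` gives 49300 nM

On these two numbers, compound 2 cannot be separated from compound 1. Compound 3 `Cc1ccc(CSc2nnc(-c3ccc4c(c3)OCCO4)n2-c2ccccc2)cc1` differs from compound 2 by one group: 4-methylphenyl in place of 3-nitrophenyl on a saturated chain carbon bound to a sulfur. Among the compounds with values here, one measured step bears on this, a 1.2-fold lower number from compound 1 to compound 2 (0.09 log units; within the scatter), for 3-nitrobenzyl in place of hydrogen on a sulfur. No measurement tests the exchange itself, so nothing beyond the scatter is expected in this assay. The expected step is a 1.1-fold lower number from compound 2 to compound 3 (0.04 log units; within the scatter). Compound 3 is estimated at 45000 nM, with an expected range from 15000 nM to 90000 nM.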

Compound 3, half-maximal inhibitory concentration: 56800 nM
The estimate for compound 3 lay 1.3-fold (0.10 log units) below the measured number; the measured number falls inside the stated range.
By their numbers in this assay, from the lowest: compounds 2, 3 and 1 (each within the scatter of the next).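

In this assay the exchange itself now shows a 1.2-fold higher number from compound 2 to compound 3 (0.06 log units; within the scatter) for 4-methylphenyl in place of 3-nitrophenyl on a saturated chain carbon bound to a sulfur, so this swap stays within the scatter. Likewise, a 1.1-fold lower number from compound 1 to compound 3 (0.02 log units; within the scatter) stands for 4-methylbenzyl in place of hydrogen on a sulfur, so a second benzyl group also cannot be separated from the hydrogen. Nothing available offers an explanation for these results. As far as these compounds go, whether an amine, a carboxylic acid or a longer chain on that sulfur would move the number beyond the scatter stays open.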